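The compounds below may be only part of what the source reports. "The series", "measured", "known", "first", "only" and "open" are said of these compounds alone.

Of the compounds shown here, three have been measured so far in a functional assay on SK-MEL-28 cells (Homo sapiens) for cytotoxicity, read by MTT assay, with a stated time of 3 days; a higher number here means a weaker inhibitor, a lower number a stronger inhibitor.

- Compound 1 `N#Cc1c(Cl)nc(SCc2nc3ccccc3[nH]2)nc1-c1ccccc1` gives 3.28 nM
- Compound 2 `N#Cc1c(NN)nc(SCc2nc3ccccc3[nH]2)nc1-c1ccccc1` gives 3 nM
- Compound 3 `CN1CCN(c2nc(SCc3nc4ccccc4[nH]3)nc(-c3ccccc3)c2C#N)CC1` gives 20 nM

Compound 3 has the highest number of the three, so it is the weakest inhibitor of this small set. Compound 1 and compound 2 do not separate: a 1.1-fold lower number from compound 1 to compound 2 (0.04 log units; within the scatter). The two steps that bring in the 4-methylpiperazin-1-yl group are modest but real: a 6.1-fold higher number from compound 1 to compound 3 (0.79 log units; beyond the scatter), and a 6.7-fold higher number from compound 2 to compound 3 (0.82 log units; beyond the scatter).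

The next compound, compound 4 `Cc1ccc(S(=O)(=O)N2CCN(c3nc(SCc4nc5ccccc5[nH]4)nc(-c4ccccc4)c3C#N)CC2)cc1`, carries (4-methylphenyl)sulfonyl in place of methyl on an amine nitrogen in a ring. Going by the values given here, no measured step changes anything at this nitrogen, so the evidence is only indirect. Among the compounds with values here, the sole guide is the modest size of the changes seen elsewhere on the core, as in a 6.7-fold higher number from compound 2 to compound 3 (0.82 log units; beyond the scatter). A step of that size or smaller is therefore expected, leaning towards a higher number, with a wide margin either way. The expected change is a 1.8-fold higher number from compound 3 to compound 4 (0.24 log units; within the scatter), which would stay within the scatter. For compound 4 the estimated value is 35 nM, with an expected range of 7 nM to 180 nM.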

Compound 4, half-maximal inhibitory concentration: 4.38 nM
For compound 4 the middle estimate is 8.0-fold (0.90 log units) above the measured one, outside the stated range (below it).
By their numbers in this assay, from the lowest: compounds 2, 1 and 4 (each within the scatter of the next); then compound 3.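

In this assay, going by these compounds alone, the amine nitrogen in the ring had so far been seen only with methyl on it, and compound 4 shows that this position accepts a much larger group: (4-methylphenyl)sulfonyl, with 10 heavy atoms and one aromatic ring, in place of methyl, with 1 heavy atom, gives a 4.6-fold lower number from compound 3 to compound 4 (0.66 log units; beyond the scatter). The step runs towards a stronger inhibitor, so the higher number of compound 3 does not come with this ring as such, and what sits on its far nitrogen changes the result. Compound 4, at 4.38 nM, lies within the scatter of compound 1, at 3.28 nM, so the ring with this larger group stands level with the chloro compound. No measurement shown here accounts for this step.

Still open, as far as these compounds go, is which part of the new group matters, the sulfonyl or the 4-methylphenyl ring: methanesulfonyl on the same nitrogen would keep the first without the second, and benzyl the second without the first. A free amine hydrogen at this nitrogen, with nothing attached, would show how the ring behaves without either group.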